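The source may hold more compounds than are shown below. What is called first, only, known or untested is meant among the compounds shown, and "the series" means these compounds.

Of the compounds shown here, three have been measured in a functional assay on UACC-62 cells (Homo sapiens) for inhibition, read by sulforhodamine B assay, with a stated time of 48 h; a higher number here means that more compound is tolerated, a lower number that less compound is tolerated. Compound 1 `Nc1cc(N)c2nc(-c3ccccc3)c(NCc3ccc(Cl)c(Cl)c3)nc2c1` gives 67600 nM in this assay, compound 2 `Nc1cc(N)c2nc(-c3ccccc3)c(Sc3ccc(F)cc3)nc2c1` gives 60300 nM, and compound 3 `COc1cc(CNc2nc3cc(N)cc(N)c3nc2-c2ccccc2)cc(OC)c1OC` gives 29500 nM. Among these three numbers compound 2 stands second highest: its result and that of compound 1 lie within the scatter of each other, whereas compound 3 gives a lower number than compound 2, a gap beyond the scatter.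

The next compound, compound 4 `Nc1cc(N)c2nc(-c3ccccc3)c(Sc3ccc(Cl)c(Cl)c3)nc2c1`, has not been measured. It differs from compound 2 in one place: 3,4-dichlorophenyl in place of 4-fluorophenyl on a sulfur. Among the compounds with values here, no measured pair in this set shows the same change directly. The nearest hint is compound 1, which carries the 3,4-dichlorophenyl group on a different linker and gives 67600 nM, close to compound 2. On that basis the step from compound 2 to compound 4 is expected to be small, either none beyond the scatter or a modest rise, and is estimated as a 1.2-fold higher number from compound 2 to compound 4 (0.06 log units; within the scatter). Compound 4 is accordingly expected to give about 70000 nM in this assay, within a range from 35000 nM to 140000 nM.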

Compound 4, concentration lethal to 50% of the cells: < 100000 nM
Compound 4: a limit, no number; the forecaster's own chance of this, stated with the estimate: 10%; the middle value is on the limit's open side.
By their numbers in this assay, from the lowest: compound 3; then compounds 2 and 1 (each within the scatter of the next).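

In this assay compound 4 gives < 100000 nM, which is a limit and not a number. The step from compound 2 to compound 4 cannot be read from it. The compounds shown leave open how (3,4-dichlorophenyl)sulfanyl compares with (4-fluorophenyl)sulfanyl on the shared core.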